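Swapping the indole for methoxyphenyl on the shared core

The source may report more compounds than this note shows. Statements on the series, on what has been measured and on what is new or still open speak of the compounds shown alone.

Among the compounds with values here, compound 3 `COc1cc(-c2ccnc3cc(-c4ccc5c(ccn5C)c4)nn23)cc(OC)c1OC` has the lowest number among the compounds measured so far in a functional assay on B16-F0 cells (Mus musculus) for inhibition, read by CCK-8 assay, with a stated time of 48 h (on this read-out lower numbers stand for stronger inhibition and higher numbers for weaker inhibition), where compound 3 gives 48 nM. Its nearest neighbour is compound 2 `Cn1ccc2cc(-c3cc4nccc(-c5ccc(F)cc5)n4n3)ccc21`, which in this assay gives 4780 nM, a gap well beyond the usual scatter. Compound 1 `COc1cc(-c2cc3nccc(-c4cc(OC)c(OC)c(OC)c4)n3n2)cc(OC)c1OC` reaches only a limit of the assay, with the value > 10000 nM in this assay; that limit is described as the limit of > 10000 nM in this assay, at which 1 of the 3 values shown sits.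

The step to compound 4 `COc1ccc(-c2cc3nccc(-c4cc(OC)c(OC)c(OC)c4)n3n2)cc1` changes one group on the shared core: 4-methoxyphenyl in place of 1-methyl-1H-indol-5-yl on an aromatic carbon. Within the data shown here, no measured pair shows this exact change, so the size of the step is open. What the numbers do show is that compound 3, the only one carrying the 1-methyl-1H-indol-5-yl together with the trimethoxyphenyl group, stands far ahead of compound 2 at 4780 nM. Compound 1, for its part, reaches only a limit of the assay. Compound 4 is therefore expected to lose potency, with a step of a 31-fold higher number from compound 3 to compound 4 (1.49 log units; beyond the scatter) in this assay. The estimate for compound 4 is 1500 nM, with a range from 200 nM to 10000 nM, and some chance that only a limit is reported.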

Compound 4, half-maximal inhibitory concentration: 1410 nM
Compound 4: middle estimate off by 1.1-fold (0.03 log units), on the high side, within the range that was stated.
By their numbers in this assay, from the lowest: compound 3; then compound 4; then compound 2. At a limit, above all of these: compound 1.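

With the trimethoxyphenyl group held in place on the shared core, placing 4-methoxyphenyl where 1-methyl-1H-indol-5-yl stood gives, in this assay, a 29-fold higher number from compound 3 to compound 4 (1.47 log units; beyond the scatter) and so shows that potency in this series depends heavily on the group at this aromatic carbon. The two groups match in hydrogen-bond donors, hydrogen-bond acceptors and net charge, while the entering group has one six-membered aromatic ring and the leaving group also has a five-membered aromatic ring with its nitrogen, so those matching counts do not by themselves predict the size of the step. Compound 1, which has a trimethoxyphenyl group at this position, gives only a limit of > 10000 nM and therefore cannot be placed by an exact number.

The measurements shown offer no reason why the indole group gives the lower number. On these data alone, it remains open how this position would respond to a 4-aminophenyl group, a 4-carboxyphenyl group, or an indol-5-yl group with an ethyl chain in place of the methyl.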